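The source may hold more compounds than are shown below. What is called first, only, known or untested is meant among the compounds shown, and "the series" means these compounds.

The four compounds share one core and differ only in the group carried on the benzyl ring. In an ADME assay on Huh-7 cells (Homo sapiens) for cytotoxicity (on this read-out higher numbers stand for weaker inhibition of growth and lower numbers for stronger inhibition of growth), compound 1, `COc1cc2c(=O)c(C(=O)c3ccc(C)cc3)cn(Cc3ccc(S(N)(=O)=O)cc3)c2cc1OC`, gives only a limit, > 25000 nM. Compound 2, `COc1cc2c(=O)c(C(=O)c3ccc(C)cc3)cn(Cc3ccc(C(C)C)cc3)c2cc1OC`, gives 15500 nM in this assay. Compound 3, `COc1cc2c(=O)c(C(=O)c3ccc(C)cc3)cn(Cc3ccc(Cl)c(Cl)c3)c2cc1OC`, has no number at all in this assay; its entry reads "not active" (no number reported). Compound 4, `COc1cc2c(=O)c(C(=O)c3ccc(C)cc3)cn(Cc3ccc(Cl)cc3)c2cc1OC`, has not yet been measured.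

The change from compound 3 to compound 4 is hydrogen in place of chloro on an aromatic carbon, that is, 3,4-dichlorobenzyl to 4-chlorobenzyl. Within the data shown here, the only measured step in this assay, an at least 1.6-fold lower number from compound 1 to compound 2 (0.20 log units; that floor lies within the scatter), concerns a different group and starts from the limit recorded as the limit of > 25000 nM in this assay, at which 1 of the 3 values shown sits; no measured step removes a chloro group, so nothing directly bears on this change. Every value shown in this assay is weak. Compound 4 is therefore expected to give a weak number as well, quite possibly again only a limit. The estimate for compound 4 in this assay is 20000 nM, expected to lie between 8000 nM and 50000 nM.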

Compound 4, concentration for 50% growth inhibition: 15500 nM
Compound 4: the middle estimate sits 1.3-fold (0.11 log units) above what was measured, within the range that was stated.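

Among these compounds, compound 4 gives the first number for a chloro-bearing benzyl group in this assay, but the change from 3,4-dichlorobenzyl to 4-chlorobenzyl cannot be read: compound 3 has no number. Replacing isopropyl with chloro shows no change at the digits printed from compound 2 to compound 4 (within the scatter), so this assay does not separate these two groups at this position. Replacing sulfamoyl with chloro gives an at least 1.6-fold lower number from compound 1 to compound 4 (0.20 log units; that floor lies within the scatter), so no difference between these two groups is established either.

Going by these compounds, compound 1 remains a limit, which leaves the true size of that step open: the limit of > 25000 nM in this assay, at which 1 of the 4 values shown sits. How an amine or a carboxylic acid in place of the chloro of compound 4 would read in this assay also remains open.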